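Pyridin-2-yl versus pyrimidin-2-yl on the piperazine nitrogen

The compounds below may be only part of what the source reports. "The series", "measured", "known", "first", "only" and "open" are said of these compounds alone.

Measured compounds:
compound 1 `Cc1c(C)c2c(c(C)c1O)CCC(C)(C(=O)N1CCN(c3ccccn3)CC1)O2`, 1000 nM in a functional assay (brain) for inhibition, with Rattus norvegicus as the target; on this read-out higher numbers stand for weaker inhibition and lower numbers for stronger inhibition
compound 2 `Cc1c(C)c2c(c(C)c1O)CCC(C)(C(=O)N1CCN(c3ncccn3)CC1)O2`, 23000 nM in this assay
compound 3 `Cc1c(C)c2c(c(C)c1O)CCC(C)(CN1CCN(c3ccccn3)CC1)O2`, 1000 nM in this assay

Compound 1 and compound 2 differ in one place, (pyrimidin-2-yl in place of pyridin-2-yl on an amine nitrogen in a ring), and this change gives a 23-fold higher number from compound 1 to compound 2 (1.36 log units; beyond the scatter). Compound 3 carries a different core from compound 1; the difference between the two cores is not broken down here, and in this assay compound 3 and compound 1 give the same number at the digits shown. Compound 4 `Cc1c(C)c2c(c(C)c1O)CCC(C)(CN1CCN(c3ncccn3)CC1)O2`, not yet measured, stands to compound 3 as compound 2 stands to compound 1: pyrimidin-2-yl in place of pyridin-2-yl on an amine nitrogen in a ring, the same change at the same place. Among the compounds with values here, with the step of a 23-fold higher number from compound 1 to compound 2 (1.36 log units; beyond the scatter) as the only guide, the step from compound 3 to compound 4 is expected to be of like size, a 20-fold higher number from compound 3 to compound 4 (1.30 log units; beyond the scatter). Compound 4 is therefore estimated at 20000 nM in this assay, with a range of 5000 nM to 60000 nM.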

Compound 4, half-maximal inhibitory concentration: 1000 nM
Compound 4: the middle estimate sits 20-fold (1.30 log units) above what was measured, outside the stated range (below it).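

In this assay, pyrimidin-2-yl in place of pyridin-2-yl on an amine nitrogen in a ring gives no change at the digits printed from compound 3 to compound 4 (within the scatter), so the large step seen on the core of compound 1 does not carry over to the core of compound 3. The same change therefore reads differently on the two cores: the same change on two cores in this assay, a 23-fold higher number (1.36 log units; beyond the scatter) from compound 1 to compound 2 and no change at the digits printed (within the scatter) from compound 3 to compound 4, 23-fold (1.36 log units) apart, beyond the scatter of two such steps. This rests on one pair per core; it gives no reason for the difference and does not say how the change would read on any further core.

The compounds shown leave open whether phenyl or pyrazin-2-yl on that amine nitrogen would also separate the two cores. They also leave open whether a longer chain from the core to the ring nitrogen would do so.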